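Compound 3 Joins Two Analogues of a Shared Core

The source may hold more compounds than are shown below. What is called first, only, known or untested is meant among the compounds shown, and "the series" means these compounds.

Compound 1 `O=C(CI)NCCCCCC(=O)NCCCCCCNc1ncnc2c1ncn2[C@@H]1O[C@H](COP(=O)(O)OP(=O)(O)OP(=O)(O)O)[C@@H](O)[C@H]1O` and compound 2 `Nc1ncnc2c1nc(NCCCCNC(=O)CI)n2[C@@H]1O[C@H](COP(=O)(O)OP(=O)(O)OP(=O)(O)O)[C@@H](O)[C@H]1O` share a core and were both examined in an assay on isolated protein for inhibition of hexokinase-1 (Rattus norvegicus), with a stated time of 6 h, tested at 10 mM; on this read-out lower numbers stand for less inhibition and higher numbers for more inhibition at the one concentration tested (going by the name of the read-out). In this assay compound 1 gives 0%, and in this assay compound 2 gives 0%, so compound 1 stands level with compound 2 within the scatter. Compound 3 `O=C(CI)NCCC(=O)NCCCCCCNc1ncnc2c1ncn2[C@@H]1O[C@H](COP(=O)(O)OP(=O)(O)OP(=O)(O)O)[C@@H](O)[C@H]1O` differs from compound 1 by ((iodomethyl)carbonyl)amino in place of 3-(((iodomethyl)carbonyl)amino)propyl on a saturated chain carbon, two bonds along the chain from a carbonyl carbon, on a saturated chain carbon two bonds along the chain from a carbonyl carbon. Among the compounds with values here, no step between measured compounds is known, and with both measured readings at the floor, no movement beyond the scatter is expected. Compound 3 is therefore expected to give 0%, between 0% and 10%, the expected step of no change at the digits printed from compound 1 to compound 3 (within the scatter) being none beyond the scatter.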

Compound 3, a percentage reported as inhibition, at one concentration (the size of the read-out at that concentration, not a potency): 0%
Beside the measured number, compound 3's estimate shows no gap at the digits printed; the measured number falls inside the stated range.
By their numbers in this assay, from the lowest: compounds 1, 2 and 3 (each within the scatter of the next).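

In this assay, putting ((iodomethyl)carbonyl)amino in place of 3-(((iodomethyl)carbonyl)amino)propyl on a saturated chain carbon, two bonds along the chain from a carbonyl carbon, gives no change at the digits printed from compound 1 to compound 3 (within the scatter). Within the data shown here, this is the only step read at this position, and it shows that shortening the chain here brings no measurable inhibition. Nothing available explains this result. From the compounds shown here alone, whether an amine or a carboxylic acid at this position would give any inhibition remains open. So does whether a longer chain would.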